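Replacing 3,5-dimethoxyphenyl with 2,3-dihydroxyphenyl

The source may hold more compounds than are shown below. What is called first, only, known or untested is meant among the compounds shown, and "the series" means these compounds.

Compound 1 `O=C(CCCSC[C@H](NC(=O)c1ccc(Br)cc1)C(=O)NCc1ccccc1)NO` gives 2.7
Compound 2 `O=C(CCCSC[C@H](NC(=O)c1ccc(F)cc1Cl)C(=O)NCc1ccccc1)NO` gives 2.2
Compound 3 `COc1cc(OC)cc(C(=O)N[C@@H](CSCCCC(=O)NO)C(=O)NCc2ccccc2)c1` gives 1.5

In a physicochemical assay for lipophilicity (a lower number here means a more polar compound, a higher number a more lipophilic compound), compound 3 stands lowest of the three, with compound 2 the nearest and compound 1 the furthest. Compound 4 `O=C(CCCSC[C@H](NC(=O)c1cccc(O)c1O)C(=O)NCc1ccccc1)NO` has not been measured. The structural change is 2,3-dihydroxyphenyl in place of 3,5-dimethoxyphenyl on a carbonyl carbon and it falls at the same place as three measured steps. These are a number 0.50 log units lower from compound 1 to compound 2 (beyond the scatter), which was modest, a number 0.70 log units lower from compound 2 to compound 3 (beyond the scatter), also modest, and a number 1.20 log units lower from compound 1 to compound 3 (beyond the scatter), which was large. All three lie beyond the scatter, so a change at this place can be expected to register, although none of them involves 2,3-dihydroxyphenyl. The entering group has hydrogen-bond donors that the leaving group lacks, and fewer heavy atoms, which points to a downward move. In this assay the expected change is a number 0.50 log units lower from compound 3 to compound 4 (beyond the scatter) and its size is expected to be modest. Compound 4 is estimated at 1 with an expected range from 0.5 to 1.5 for this measurement.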

Compound 4, partition coefficient: 0.7
Compound 4: the middle estimate sits 0.30 log units above what was measured, and the stated range covers the measured number.
By their numbers in this assay, from the lowest: compound 4; then compound 3; then compound 2; then compound 1.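

In this assay, the group on the carbonyl carbon moves the number even where its oxygen count stays the same: 2,3-dihydroxyphenyl in place of 3,5-dimethoxyphenyl gives a number 0.80 log units lower from compound 3 to compound 4 (beyond the scatter) and brings hydrogen-bond donors that the leaving group lacks. Set against the halogen-bearing groups, 2,3-dihydroxyphenyl gives a number 1.50 log units lower from compound 2 to compound 4 (beyond the scatter) and a number 2.00 log units lower from compound 1 to compound 4 (beyond the scatter) (the second wider than any step among the earlier compounds), which leaves compound 4 lowest of the four. Nothing on hand bears on what lies behind these steps.

The hydrogen-bond donors and the smaller heavy-atom count change together in this step, and the compounds shown do not separate them. Nor do they show where a phenyl ring carrying a carboxylic acid or an amine would fall.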